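A few compounds are considered here, and "the series" means these few. Any claim that something is new, unique, unknown or untested is made for them only; others in the source may bear on it.

Compound 1 `COc1ccc(NC(=O)c2csc(Cc3c(Cl)cccc3Cl)n2)cc1` was tested in an assay on CHO cells, read by calcium flux; a higher number here means a weaker inhibitor, a lower number a stronger inhibitor. In this assay compound 1 gives > 4000 nM, which is a limit of the assay rather than a number (the limit of > 4000 nM in this assay, at which 1 of the 2 values shown sits). Compound 2 `O=C(Nc1ccc(C(F)(F)C(F)(F)F)cc1)c1csc(Cc2c(Cl)cccc2Cl)n1` in this assay gives 350 nM, and the step of an at least 11-fold lower number from compound 1 to compound 2 (1.05 log units; beyond the scatter) is the only measured one. Compound 3 `O=C(Nc1ccccc1Br)c1csc(Cc2c(Cl)cccc2Cl)n1` differs from compound 1 by 2-bromophenyl in place of 4-methoxyphenyl on an amide-type nitrogen. The measured step removed the same 4-methoxyphenyl but brought in a different group, so it bears on compound 3 only loosely. A modest lowering is expected for compound 3, an at least 2.0-fold lower number from compound 1 to compound 3 (0.30 log units; that floor lies within the scatter). Compound 3 is estimated at 2000 nM, between 500 nM and 8000 nM, in this assay.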

Compound 3, half-maximal inhibitory concentration: > 4000 nM
Compound 3 ended at the assay's limit; the forecaster's own chance of this, stated with the estimate: 40%; at least 2.0-fold (0.30 log units) between middle value and limit.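

In this assay, within the data shown here, compound 3 gives > 4000 nM, which is a limit of the assay and not a number; compound 1 also sits at this limit, so no step between compound 1 and compound 3 can be read. The compounds shown leave open how 2-bromophenyl and 4-methoxyphenyl compare on the amide-type nitrogen.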